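Methoxy to Trifluoromethyl on the Pyridinyl Arm

A few compounds are considered here, and "the series" means these few. Any claim that something is new, unique, unknown or untested is made for them only; others in the source may bear on it.

In a functional assay on U2OS cells for antagonist activity at C-X-C chemokine receptor type 3 (Homo sapiens), read by beta-arrestin recruitment (on this read-out lower numbers stand for stronger inhibition and higher numbers for weaker inhibition), compound 3 `COc1ccc(-c2nc(C(F)(F)F)sc2N2CCN(C(=O)Cn3nc(C)nc3C)[C@H](C)C2)cn1` gives 1170 nM, the highest number of the three measured; compound 1 `CCOc1ncc(-c2nc(C(F)(F)F)sc2N2CCN(C(=O)Cn3nc(C)nc3C)[C@H](C)C2)cn1` gives 173 nM and compound 2 `COc1ncc(-c2nc(C(F)(F)F)sc2N2CCN(C(=O)Cn3nc(C)nc3C)[C@H](C)C2)cn1` gives 558 nM. The measured steps run a 3.2-fold higher number from compound 1 to compound 2 (0.51 log units; beyond the scatter), a 6.8-fold higher number from compound 1 to compound 3 (0.83 log units; beyond the scatter) and a 2.1-fold higher number from compound 2 to compound 3 (0.32 log units; beyond the scatter). Compound 4 `Cc1nc(C)n(CC(=O)N2CCN(c3sc(C(F)(F)F)nc3-c3ccc(C(F)(F)F)nc3)C[C@H]2C)n1` differs from compound 3 by trifluoromethyl in place of methoxy on an aromatic carbon. Among the measured compounds shown here, none of the measured steps exchanges methoxy for trifluoromethyl; they vary only the alkoxy chain or replace 2-alkoxypyrimidin-5-yl with 6-methoxypyridin-3-yl, so they set no direction for this change. Compound 4 is therefore expected to show a step of a 1.2-fold lower number from compound 3 to compound 4 (0.07 log units; within the scatter) in this assay, within the modest range already seen. The estimate for compound 4 is 1000 nM, ranging from 300 nM to 4000 nM.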

Compound 4, half-maximal inhibitory concentration: 608 nM
Estimate against measurement, compound 4: 1.6-fold (0.22 log units) above; low and high end bracket the measured number.
By their numbers in this assay, from the lowest: compound 1; then compounds 2, 4 and 3 (each within the scatter of the next, the first and the last beyond it).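

Trifluoromethyl is accepted on this aromatic carbon next to the ring nitrogen in this assay, where the exchange for methoxy gives a 1.9-fold lower number from compound 3 to compound 4 (0.28 log units; within the scatter) and so shows that the methoxy oxygen is not required here. The 6-(trifluoromethyl)pyridin-3-yl arm also stays level with the 2-methoxypyrimidin-5-yl arm, with a 1.1-fold higher number from compound 2 to compound 4 (0.04 log units; within the scatter) but not with the 2-ethoxypyrimidin-5-yl arm, with a 3.5-fold higher number from compound 1 to compound 4 (0.55 log units; beyond the scatter). No supporting measurement accounts for these steps. Still open, going by these compounds, is how an amine, a nitrile or a longer fluoroalkyl chain would read at this carbon. Also open, on these data alone, is whether trifluoromethyl would give the same result on the 2-methoxypyrimidin-5-yl arm.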